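Extending an alkyl chain on a bromomaleimide-bearing indole series

The source may hold more compounds than are shown below. What is called first, only, known or untested is meant among the compounds shown, and "the series" means these compounds.

Measured compounds:
Compound 1, `Cc1ccc2[nH]c(-c3ccccc3)c(C3=C(Br)C(=O)NC3=O)c2c1`: 2.88
Compound 2, `CCc1ccc2[nH]c(-c3ccccc3)c(C3=C(Br)C(=O)NC3=O)c2c1`: 3.15
Compound 3, `CCc1ccc2[nH]c(-c3ccc(OC)cc3)c(C3=C(Br)C(=O)NC3=O)c2c1`: 3.23

Of the compounds shown here, three have been measured in a physicochemical assay for lipophilicity; a higher number here means a more lipophilic compound, a lower number a more polar compound. Compound 1, `Cc1ccc2[nH]c(-c3ccccc3)c(C3=C(Br)C(=O)NC3=O)c2c1`, gives 2.88 in this assay. Compound 2, `CCc1ccc2[nH]c(-c3ccccc3)c(C3=C(Br)C(=O)NC3=O)c2c1`, carries methyl in place of hydrogen on a saturated chain carbon bound to an aromatic carbon and gives 3.15; the step is a number 0.27 log units higher from compound 1 to compound 2 (within the scatter). Compound 3, `CCc1ccc2[nH]c(-c3ccc(OC)cc3)c(C3=C(Br)C(=O)NC3=O)c2c1`, gives 3.23, the step being a number 0.08 log units higher from compound 2 to compound 3 (within the scatter). The difference between compound 1 and compound 3 is not broken down here. Compound 3 has the highest of the three numbers, and only compound 1 lies beyond the scatter from it.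

Compound 4, `CCCc1ccc2[nH]c(-c3ccc(OC)cc3)c(C3=C(Br)C(=O)NC3=O)c2c1`, has not yet been measured in this assay. It differs from compound 3 by methyl in place of hydrogen on a saturated chain carbon, two bonds along the chain from an aromatic carbon. Among the measured compounds shown here, this is the same kind of change as the one from compound 1 to compound 2, but not the same: in the earlier pair the new methyl sits on a saturated chain carbon bound to an aromatic carbon, whereas here it sits on a saturated chain carbon two bonds along the chain from an aromatic carbon. Read one bond further out, the earlier change is methyl to ethyl and the new one ethyl to propyl.

Because a number 0.27 log units higher from compound 1 to compound 2 (within the scatter), a step of similar size is expected from compound 3 to compound 4, namely a number 0.32 log units higher from compound 3 to compound 4 (beyond the scatter). Compound 4 is estimated to give 3.55 in this assay, with a likely range from 3.25 to 3.85.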

Compound 4, partition coefficient: 3.45
Estimate against measurement, compound 4: 0.10 log units above; the range from low to high includes it.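

In this assay the new step reads a number 0.22 log units higher from compound 3 to compound 4 (within the scatter) and sits alongside the earlier reading of a number 0.27 log units higher from compound 1 to compound 2 (within the scatter) on the core of compound 1, so the two readings agree in sign, though neither separates its own pair of compounds from the scatter of the measurement. Among the compounds shown here, this is compatible with the added methyl carrying over from one core to the other, but it does not establish that, since it rests on only two pairs that differ in the core, which carries a methoxy group in compound 3 and compound 4, and in the change itself, methyl to ethyl in one pair and ethyl to propyl in the other. Nothing available bears on why the two steps read as they do.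

The compounds shown contain no pair with the same chain change on both cores, so the contribution of the core cannot be told apart from that of the chain. They also leave open how a butyl chain, or a chain ending in an amine or a carboxylic acid, would read in this assay on either core.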